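Hydroxy addition to the 4-methoxyphenyl group of compound 3

The source may report more compounds than this note shows. Statements on the series, on what has been measured and on what is new or still open speak of the compounds shown alone.

In a functional assay on CCRF-CEM cells (Homo sapiens) for cytotoxicity (on this read-out higher numbers stand for lower toxicity in this test and lower numbers for higher toxicity in this test), compound 3 (`COc1ccc(/C=N/c2nc(NC3CC3)c3ncn(C4C=CC(CO)C4)c3n2)cc1`) gives > 100000 nM, which is a limit and not a number. Compound 1 (`Cc1ccc(/C=N/c2nc(NC3CC3)c3ncn(C4C=CC(CO)C4)c3n2)cc1`) gives > 100000 nM, which is also a limit. The series therefore stands largely at the limit of > 100000 nM in this assay, at which 2 of the 3 values shown sit. Within the data shown here, compound 2 (`O=[N+]([O-])c1ccccc1/C=N/c1nc(NC2CC2)c2ncn(C3C=CC(CO)C3)c2n1`) gives 13000 nM, the only true number so far.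

Compound 4 (`COc1ccc(/C=N/c2nc(NC3CC3)c3ncn(C4C=CC(CO)C4)c3n2)c(O)c1`) carries hydroxy in place of hydrogen on an aromatic carbon, ortho to a large group and meta to a methoxy group, so that 4-methoxyphenyl becomes 2-hydroxy-4-methoxyphenyl: hydroxy in place of hydrogen on an aromatic carbon.

The closest measured change, a step that the two limits leave unreadable from compound 1 to compound 3, also falls on an aromatic carbon but gives no size. The informative steps are an at least 7.6-fold lower number from compound 1 to compound 2 (0.88 log units; beyond the scatter) and an at least 7.6-fold higher number from compound 2 to compound 3 (0.88 log units; beyond the scatter), both of which exchange the whole aryl group. Among the measured compounds shown here, they show that this group can move the read-out, and compound 2, with its 2-nitrophenyl group, is the one compound that departs from the limit. Compound 4 also has a substituent named at the 2 position, but a hydroxy group is not a nitro group, so only a modest move toward lower numbers in this assay is expected, and another limit remains quite possible.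

The expected step is an at least 2.0-fold lower number from compound 3 to compound 4 (0.30 log units; that floor lies within the scatter).

The estimate for compound 4 is 50000 nM, with an expected range from 13000 nM to 150000 nM.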

Compound 4, half-maximal cytotoxic concentration: 100000 nM
For compound 4 the middle estimate is 2.0-fold (0.30 log units) below the measured one; measured number inside the range.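

In this assay compound 4 gives 100000 nM, a true number, with hydroxy in place of hydrogen on an aromatic carbon, ortho to a large group and meta to a methoxy group. Compound 3 gives > 100000 nM, which is a limit. The hydroxy change is a number no higher from compound 3 to compound 4 (the limit leaves the size open), and the wider change of aryl group is a number no higher from compound 1 to compound 4 (the limit leaves the size open); neither size can be read, so the data do not show whether the hydroxy group moved the number at all. The one readable step is a 7.7-fold higher number from compound 2 to compound 4 (0.89 log units; beyond the scatter), so 2-hydroxy-4-methoxyphenyl does not bring the read-out close to the value given by 2-nitrophenyl, and the series still stands largely at the top of the measurable range: the limit of > 100000 nM in this assay, at which 2 of the 4 values shown sit.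

The compounds shown leave open whether an amine or a carboxylic acid in place of the hydroxy group would give a lower number on this read-out. Also open, on these data alone, is how a 2-hydroxyphenyl group without the methoxy group would read, and whether the number of compound 2 depends on the nitro group itself.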